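Swapping the hydrazone aryl: an expected modest gain

This account rests on a few compounds, and the source may have more. Where it says the series, first, only, none or still open, it means among the compounds named here.

Compound 1 `C#CCSc1nc(N/N=C/c2ccc(N(C)C)cc2)c2nnn(Cc3ccccc3)c2n1` was tested in a functional assay on MGC-803 cells (Homo sapiens) for antiproliferative activity, read by MTT assay, with a stated time of 72 h (on this read-out lower numbers stand for stronger inhibition and higher numbers for weaker inhibition), where compound 1 gives 7620 nM. Among the three compounds with numbers in hand, compound 1 stands second highest. Its nearest neighbour is compound 3 `C#CCSc1nc(N/N=C(\C)c2ccccc2O)c2nnn(Cc3ccccc3)c2n1`, which in this assay gives 3820 nM; the gap between the two lies within the scatter, so no order can be read from it. Furthest from compound 1 is compound 2 `CCCSc1nc(N/N=C(\C)c2ccccc2O)c2nnn(Cc3ccccc3Cl)c2n1`, which in this assay gives 35000 nM, a gap that lies beyond the scatter.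

Compound 4 `C#CCSc1nc(N/N=C/c2c(O)ccc3ccccc23)c2nnn(Cc3ccccc3)c2n1` has not yet been measured. It differs from compound 1 in one place: 2-hydroxynaphthalen-1-yl in place of 4-(dimethylamino)phenyl on a carbon with a double bond to nitrogen. Among the compounds with values here, no single-change step between measured compounds exists that would calibrate this change, so the expectation rests on the whole set, in which a hydroxyl-bearing aryl group is present in compound 3, the compound with the lowest number, and in compound 2, the compound with the highest number.

On that basis compound 4 is expected to land close to compound 1, with a step of a 1.5-fold lower number from compound 1 to compound 4 (0.18 log units; within the scatter) that is estimated to be small and, if anything, toward a lower number. The estimate for compound 4 in this assay is 5000 nM, with a range from 1500 nM to 16000 nM.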

Compound 4, half-maximal inhibitory concentration: 10500 nM
Compound 4: the middle estimate sits 2.1-fold (0.32 log units) below what was measured, and the stated range covers the measured number.
By their numbers in this assay, from the lowest: compounds 3, 1 and 4 (each within the scatter of the next, the first and the last beyond it); then compound 2.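

In this assay, within the data shown here, the exchange of 4-(dimethylamino)phenyl for 2-hydroxynaphthalen-1-yl gives a 1.4-fold higher number from compound 1 to compound 4 (0.14 log units; within the scatter) and is the first reading of this position with the rest of compound 1 held fixed. On a carbon with a double bond to nitrogen, the dimethylamino nitrogen can thus be lost and a second six-membered aromatic ring and a hydroxyl gained, all at once, without a shift that stands clear of the scatter. Nothing measured here offers a reason for this result, so the step stands as an observation only.

The exchange alters several features together, so the compounds shown cannot say what the second ring or the hydroxyl contributes alone, and a plain phenyl or an unsubstituted naphthyl on the same carbon would begin to separate them. From the compounds shown here alone, it also remains open whether a morpholine or a carboxylic acid on the phenyl ring of compound 1 would move the number beyond the scatter, or whether this position tolerates such groups as readily as it tolerates 2-hydroxynaphthalen-1-yl.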